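A few compounds are considered here, and "the series" means these few. Any claim that something is new, unique, unknown or untested is made for them only; others in the source may bear on it.

Measured so far:
compound 1, `CC(C)C(c1nnc[nH]1)c1ccc(-c2ccc3cccc(F)c3c2)[nH]c1=O` — 0.552 h
compound 2, `CC(C)C(Nc1nccs1)c1ccc(-c2ccc3cccc(F)c3c2)[nH]c1=O` — 0.07 h
compound 3, `CC(C)C(Cc1nnn[nH]1)c1ccc(-c2ccc3cccc(F)c3c2)[nH]c1=O` — 2.08 h

All three compounds share one core and differ only in the group sitting on a saturated chain carbon bound to an aromatic carbon and a saturated chain carbon. In an ADME assay on microsomes from liver (Rattus norvegicus) for metabolic stability (a lower number here means that the compound disappears faster, a higher number that the compound lasts longer), compound 1 gives 0.552 h, the second highest of the three numbers. Compound 2 gives 0.07 h and compound 3 gives 2.08 h, so that there is a 7.9-fold lower number from compound 1 to compound 2 (0.90 log units; beyond the scatter) and a 3.8-fold higher number from compound 1 to compound 3 (0.58 log units; beyond the scatter), both beyond the usual scatter.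

Compound 4, `CC(C)C(c1cnc(N)s1)c1ccc(-c2ccc3cccc(F)c3c2)[nH]c1=O`, has not yet been measured in this assay. Compared with compound 1 the change is 2-amino-1,3-thiazol-5-yl in place of 4H-1,2,4-triazol-3-yl on a saturated chain carbon bound to an aromatic carbon and a saturated chain carbon. Going by the values given here, the step that bears most on this is the one to compound 2. The group entering there, (1,3-thiazol-2-yl)amino, is the nearest relative of 2-amino-1,3-thiazol-5-yl among the measured groups, and that step was a 7.9-fold lower number from compound 1 to compound 2 (0.90 log units; beyond the scatter). The step to compound 3 involves a tetrazole instead and is less informative here. A downward step beyond the scatter is therefore expected, though the group in compound 4 is not the same as that in compound 2, so a somewhat smaller drop seems plausible. Compound 4 is expected to give about 0.2 h, within a range of 0.06 h to 0.6 h. That estimate corresponds to a 2.8-fold lower number from compound 1 to compound 4 (0.44 log units; beyond the scatter).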

Compound 4, half-life: 0.0983 h
Compound 4: middle estimate off by 2.0-fold (0.31 log units), on the high side, and the stated range covers the measured number.
By their numbers in this assay, from the lowest: compounds 2 and 4 (each within the scatter of the next); then compound 1; then compound 3.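

In this assay the change to 2-amino-1,3-thiazol-5-yl on this saturated chain carbon gives a 5.6-fold lower number from compound 1 to compound 4 (0.75 log units; beyond the scatter) and, measured against the tetrazole-bearing compound, a 21-fold lower number from compound 3 to compound 4 (1.33 log units; beyond the scatter) so a second thiazole-bearing group now sits well below both compounds with a nitrogen-only ring. The two thiazole-bearing groups are attached differently, one through a ring carbon and carrying a free amino group, the other through its amino nitrogen, yet the step between them is a 1.4-fold higher number from compound 2 to compound 4 (0.15 log units; within the scatter) and this assay does not separate them. Across these four compounds, then, both thiazole-bearing groups give short half-lives, and neither compound 1 nor compound 3 goes against that pattern, although no measurement shown here gives a reason for it.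

Still open, going by these compounds, is whether the low numbers go with the thiazole ring itself or with the nitrogen attached to it, a question that a plain 1,3-thiazol-5-yl group on the same carbon could address. On these data alone, it is also open whether the higher number of compound 3 depends on the tetrazole or on its extra methylene, which a directly attached 1H-tetrazol-5-yl or a carboxylic acid could help to test.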